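Moving the chlorine on the thiourea aryl group

A few compounds are considered here, and "the series" means these few. Any claim that something is new, unique, unknown or untested is made for them only; others in the source may bear on it.

Measured so far:
compound 1, `COc1cccc(NC(=S)NCCNS(=O)(=O)c2ccc(-c3ccccc3Oc3ccc([N+](=O)[O-])cc3)s2)c1`, in a functional assay on RS4-11 cells (Homo sapiens) for inhibition, read by CCK-8 assay, with a stated time of 48 h (on this read-out higher numbers stand for weaker inhibition and lower numbers for stronger inhibition), gives > 50000 nM, a limit of the assay rather than a number.
compound 2, `O=S(=O)(NCCNC(=S)Nc1cccc(Cl)c1)c1ccc(-c2ccccc2OCc2ccccc2)s1`, in this assay gives > 50000 nM, again only a limit.

Among the measured compounds shown here, compound 2 therefore stands at the limit of this assay, and so does the one other value shown, as the limit of > 50000 nM in this assay, at which 2 of the 2 values shown sit, records; neither compound gives a number to compare.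

Compound 3, `O=S(=O)(NCCNC(=S)Nc1ccc(Cl)cc1)c1ccc(-c2ccccc2OCc2ccccc2)s1`, differs from compound 2 in one place: 4-chlorophenyl in place of 3-chlorophenyl on an amide-type nitrogen. The rest of the molecule is unchanged.

Since compound 2 gives only a limit, the shift of the chlorine around the aryl ring is expected to produce no step beyond the scatter, and the expected step of a number no higher from compound 2 to compound 3 (the limit leaves the size open) is none at all. Compound 3 is thus expected to give about 50000 nM, within 20000 nM to 100000 nM, and will most likely again be reported as a limit.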

Compound 3, half-maximal inhibitory concentration: > 50000 nM
Compound 3: no number, only a limit; the forecaster's own chance of this, stated with the estimate: 80%; the middle value sits exactly at the limit.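

Compound 2 and compound 3 both sit at a limit rather than a number, so no step can be read between them in this assay: the limit of > 50000 nM in this assay, at which 3 of the 3 values shown sit. The compounds shown leave open whether 3-chlorophenyl and 4-chlorophenyl differ at all, and which change to the shared core would give a measurable number.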